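Swapping the aryl group on the saturated ring carbon

The compounds below may be only part of what the source reports. "The series", "measured", "known", "first", "only" and "open" are said of these compounds alone.

The shared core is carried by compound 1 `N#CC1=C(N)OC(c2c[nH]c3ccccc23)=C(C#N)C1c1ccc2ccccc2c1`, compound 2 `COc1ccc(C2C(C#N)=C(N)OC(c3c[nH]c4ccccc34)=C2C#N)cc1OC`, compound 3 `N#CC1=C(N)OC(c2c[nH]c3ccccc23)=C(C#N)C1c1ccccc1Cl` and compound 4 `N#CC1=C(N)OC(c2c[nH]c3ccccc23)=C(C#N)C1c1ccc(F)cc1`. In a functional assay, tested at 100 ug/mL (on this read-out lower numbers stand for a weaker effect and higher numbers for a stronger effect at the one concentration tested), compound 1 gives "not active" (no number reported). For the measured compounds named here, compound 2 gives 19.1% and compound 3 gives 10.4%, so compound 3 holds one of only two numbers at hand, and the step of a number 8.7 percentage points lower from compound 2 to compound 3 (within the scatter) lies within the scatter, leaving the two indistinguishable. Compound 4 differs from compound 3 by 4-fluorophenyl in place of 2-chlorophenyl on a saturated ring carbon. Going by the values given here, the only step that bears on this is the aryl swap on the same carbon, which was within the scatter, so no step beyond the scatter is expected in this assay, namely a number 1.6 percentage points higher from compound 3 to compound 4 (within the scatter). Compound 4 is therefore estimated at 12%, between 2% and 25%.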

Compound 4, a percentage reported as activity, at one concentration (the size of the read-out at that concentration, not a potency): 16.2%
Compound 4: the middle estimate sits 4.2 percentage points below what was measured; low and high end bracket the measured number.
By their numbers in this assay, from the lowest: compounds 3, 4 and 2 (each within the scatter of the next).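

In this assay, 4-fluorophenyl in place of 2-chlorophenyl on the saturated ring carbon gives a number 5.8 percentage points higher from compound 3 to compound 4 (within the scatter), and 4-fluorophenyl in place of 3,4-dimethoxyphenyl gives a number 2.9 percentage points lower from compound 2 to compound 4 (within the scatter). The three aryl groups with numbers at this carbon therefore cannot be told apart on this read-out, whether they carry fluorine, chlorine or two methoxy groups. Any step involving compound 1 cannot be read, as it has no number.

On these data alone, whether an amine or a carboxylic acid on this aryl ring would give a step beyond the scatter stays open. Nothing available here explains the values.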